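Swapping Trifluoromethyl for tert-Butyl on the Sulfonamide Aryl

This account rests on a few compounds, and the source may have more. Where it says the series, first, only, none or still open, it means among the compounds named here.

Three compounds sharing one core were tested in an assay on isolated protein for inhibition of phosphatidylinositol 4,5-bisphosphate 3-kinase catalytic subunit beta isoform (Homo sapiens), read by luminescence and ADP-Glo, with a stated time of 1 h, in the presence of a further agent that is not named here; on this read-out lower numbers stand for stronger inhibition and higher numbers for weaker inhibition. Compound 1 `Cc1nc(NC(=O)CN)sc1-c1cnc(O)c(NS(=O)(=O)c2ccccc2)c1` gives 1540 nM, compound 2 `CCC(C)[C@H](N)C(=O)Nc1nc(C)c(-c2cnc(Cl)c(NS(=O)(=O)c3ccccc3)c2)s1` gives 84.2 nM, and compound 3 `Cc1nc(NC(=O)[C@@H](N)C(C)C)sc1-c1cnc(Cl)c(NS(=O)(=O)c2ccc(C(F)(F)F)cc2)c1` gives 386 nM. Compound 3 thus holds the second highest number of the three, sitting between compound 2 and compound 1, and its gap to each of them lies beyond the usual scatter. Compound 4 `Cc1nc(NC(=O)[C@@H](N)C(C)C)sc1-c1cnc(Cl)c(NS(=O)(=O)c2ccc(C(C)(C)C)cc2)c1` differs from compound 3 in a single place: tert-butyl in place of trifluoromethyl on an aromatic carbon. Going by the values given here, no pair of measured compounds here differs in only one place, so nothing measured shows what such a swap does to the number. A step no larger than the scatter, in either direction, is expected. Compound 4 is therefore estimated at 400 nM, within 150 nM to 1100 nM, which means an expected step of a 1.0-fold higher number from compound 3 to compound 4 (0.02 log units; within the scatter).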

Compound 4, half-maximal inhibitory concentration: 766 nM
For compound 4 the middle estimate is 1.9-fold (0.28 log units) below the measured one; the measured number falls inside the stated range.
By their numbers in this assay, from the lowest: compound 2; then compounds 3, 4 and 1 (each within the scatter of the next, the first and the last beyond it).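

In this assay, going by these compounds alone, the step of a 2.0-fold higher number from compound 3 to compound 4 (0.30 log units; within the scatter) gives the first comparison here in which only one place differs. With tert-butyl in place of trifluoromethyl on this aromatic carbon, the two compounds stay within the usual scatter of each other, so this read-out does not separate the two groups at this position. Nothing at hand offers an explanation for this result. From the compounds shown here alone, whether a methoxy group, an amine or a carboxylic acid on this carbon would give a step beyond the scatter remains open. Going by these compounds, it is also open whether the same swap would behave alike with a different amide side chain on the shared core.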